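Shifting the methoxy on the phenoxy arm of compound 3

The source may hold more compounds than are shown below. What is called first, only, known or untested is meant among the compounds shown, and "the series" means these compounds.

Compound 3 `Cc1ccccc1-n1nc(C)c2c1NC(=O)[C@H](C)S[C@@H]2c1ccc(-c2ccsc2)cc1` reaches 68% in an assay on isolated protein for agonist activity at Bile acid receptor (Homo sapiens), read by AlphaScreen, with a stated time of 30 min (a lower number here means a smaller maximal response, a higher number a larger maximal response), the second highest of the three measured numbers. Compound 2 `COc1ccc(Oc2ccc([C@H]3S[C@@H](C)C(=O)Nc4c3c(C)nn4-c3ccccc3C)cc2)cc1` gives 70%, and the step of a number 2 percentage points lower from compound 2 to compound 3 (within the scatter) lies within the scatter. Compound 1 `Cc1ccccc1-n1nc(C)c2c1NC(=O)[C@H](C)S[C@@H]2c1ccc(-c2ccoc2)cc1` gives 40%, and the steps of a number 30 percentage points higher from compound 1 to compound 2 (beyond the scatter) and a number 28 percentage points higher from compound 1 to compound 3 (beyond the scatter) are both beyond the scatter.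

Compound 4 `COc1cccc(Oc2ccc([C@H]3S[C@@H](C)C(=O)Nc4c3c(C)nn4-c3ccccc3C)cc2)c1` differs from compound 3 in one place: 3-methoxyphenoxy in place of thiophen-3-yl on an aromatic carbon. Within the data shown here, the only step that bears on it is the exchange between the methoxyphenoxy and thiophenyl groups, a number 2 percentage points lower from compound 2 to compound 3 (within the scatter), which was within the scatter. Among the measured compounds shown here, no measured step addresses the position of the methoxy group itself. Compound 4 is therefore expected to show a step of no change at the digits printed from compound 3 to compound 4 (within the scatter), within the scatter, and an estimated value of 68%, ranging from 50% to 85%.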

Compound 4, largest response reached (reported as efficacy), in percent of the reference or control that the assay uses: 120%
Estimate against measurement, compound 4: 52 percentage points below; measured number above the stated range.
By their numbers in this assay, from the lowest: compound 1; then compounds 3 and 2 (each within the scatter of the next); then compound 4.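

In this assay, the place of the methoxy on the phenoxy arm turns out to matter: moving it alone gives a number 50 percentage points higher from compound 2 to compound 4 (beyond the scatter), whereas exchanging the whole arm had earlier left compound 2 and compound 3 within the scatter. The 3-methoxyphenoxy arm also stands clear of both five-membered aromatic rings, with a number 52 percentage points higher from compound 3 to compound 4 (beyond the scatter) and a number 80 percentage points higher from compound 1 to compound 4 (beyond the scatter). Nothing shown here explains this gain.

As far as these compounds go, whether the methoxy itself is needed remains open, since these compounds do not show a hydroxy group or an amine at that place on the ring.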